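Swapping a Benzoyl for a Hydroxyethyl Group

The source may hold more compounds than are shown below. What is called first, only, known or untested is meant among the compounds shown, and "the series" means these compounds.

Compound 1 `CC(=O)c1cccc(NC(=O)c2cc3ccccc3[nH]2)c1` and compound 2 `O=C(c1ccccc1)c1cccc(NC(=O)c2cc3ccccc3[nH]2)c1` share one core and differ only in the group on the carbonyl carbon. In a functional assay on K562 cells (Homo sapiens) for inhibition, read by MTT assay, with a stated time of 24 h (a higher number here means a weaker inhibitor, a lower number a stronger inhibitor), compound 1 gives > 100000 nM, which is a limit of the assay rather than a number. In this assay compound 2 likewise gives > 100000 nM, again a limit. The step that the two limits leave unreadable from compound 1 to compound 2 is therefore unreadable because of the limit of > 100000 nM in this assay, at which 2 of the 2 values shown sit. Compound 3 `CC(O)c1cccc(NC(=O)c2cc3ccccc3[nH]2)c1` carries the change (1-hydroxyethyl in place of benzoyl on an aromatic carbon). Among the compounds with values here, no measured step gives a readable size or direction for this change. Compound 3 is expected to give 100000 nM, with a range from 30000 nM to 300000 nM. The expected step is a number no higher from compound 2 to compound 3 (the limit leaves the size open).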

Compound 3, half-maximal inhibitory concentration: > 100000 nM
Compound 3 ended at the assay's limit (the forecaster's own chance of this, stated with the estimate: 80%); the middle value sits exactly at the limit.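

No step can be read among compound 1, compound 2 and compound 3, because each value is a limit and not a number: the limit of > 100000 nM in this assay, at which 3 of the 3 values shown sit.

From the compounds shown here alone, whether the group at this place on the shared core affects inhibition in this assay at all stays open.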